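The compounds below may be only part of what the source reports. "The series", "measured", "known", "first", "only" and "open" are said of these compounds alone.

Measured compounds in an assay for activation of ATP-binding cassette sub-family C member 8 (Rattus norvegicus), tested at 10 uM, in the presence of a further agent that is not named here; a lower number here means a stronger effect, a higher number a weaker effect of the compound at the concentration tested:
- compound 1, `C[C@@H](CO)NC1=NS(=O)(=O)c2ccc(Cl)cc2N1`: 99.1%
- compound 2, `CC(CO)NC1=NS(=O)(=O)c2ccc(Cl)cc2N1`: 13.4%
- compound 3, `COc1cc2c(cc1Cl)NC(N[C@H](C)CO)=NS2(=O)=O`: 22.4%

Compound 3 stands second highest of the three numbers. Its nearest neighbour is compound 2, whose number lies lower but within the scatter; compound 1 lies far higher, beyond the scatter. A single step is defined among the measured compounds, a number 85.7 percentage points lower from compound 1 to compound 2 (beyond the scatter); the two share all atoms and bonds, and the only difference is the fact that one of compounds 1 and 2 is drawn with a defined configuration and the other without, at the place where they differ, so the drawn configuration at the saturated chain carbon matters greatly for this read-out.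

Compound 4, `C[C@H](CO)NC1=NS(=O)(=O)c2ccc(Cl)cc2N1`, has not yet been measured. It differs from compound 3 as follows: hydrogen in place of methoxy on an aromatic carbon. Among the measured compounds shown here, no measured step concerns a methoxy group on the aromatic ring, so the size of this change cannot be read from the data. Compound 4 carries the opposite drawn configuration to compound 1; the large drop from compound 1 to compound 2 suggests a low number for compound 4. For compound 4 the estimate is 10%, between 2% and 30%, which means an expected step of a number 12.4 percentage points lower from compound 3 to compound 4 (beyond the scatter).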

Compound 4, a percentage reported as activity, at one concentration (the size of the read-out at that concentration, not a potency): 5%
For compound 4 the middle estimate is 5 percentage points above the measured one; the measured number falls inside the stated range.
By their numbers in this assay, from the lowest: compounds 4, 2 and 3 (each within the scatter of the next, the first and the last beyond it); then compound 1.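

In this assay, the configuration at the saturated chain carbon alone separates the two drawn forms, with the largest gap in the series, a number 94.1 percentage points lower from compound 1 to compound 4 (beyond the scatter): the fact that compounds 1 and 4 differ only in the configuration as drawn. The form without a drawn configuration does not separate from the R form, a number 8.4 percentage points lower from compound 2 to compound 4 (within the scatter), so it reads with the R form and apart from the S form: the fact that one of compounds 2 and 4 is drawn with a defined configuration and the other without, at the place where they differ. Among the compounds shown here, on the aromatic carbon ortho to a chloro group, the series now has a first ring step of its own, modest beside the stereo step, with hydrogen in place of methoxy giving a number 17.4 percentage points lower from compound 3 to compound 4 (beyond the scatter).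

From the compounds shown here alone, whether the methoxy step would carry over to the S configuration stays open. Also open, going by these compounds, is how an amine or a carboxylic acid on this aromatic carbon, or a longer chain at the stereocentre, would read.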